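The source may hold more compounds than are shown below. What is called first, only, known or untested is meant among the compounds shown, and "the series" means these compounds.

Three compounds that share one core and differ only in the aromatic group on it have been read in a functional assay on MDA-MB-231 cells (Homo sapiens) for antiproliferative activity, read by MTT assay, with a stated time of 48 h; a lower number here means a stronger inhibitor, a higher number a weaker inhibitor. Compound 1 (`C=CS(=O)(=O)N1CCN(c2ncnc3sc(-c4ccc(C#N)cc4)cc23)CC1`) gives 8050 nM, compound 2 (`C=CS(=O)(=O)N1CCN(c2ncnc3sc(-c4ccnc(Cl)c4)cc23)CC1`) gives 27700 nM and compound 3 (`C=CS(=O)(=O)N1CCN(c2ncnc3sc(-c4ccc(OC)nc4)cc23)CC1`) gives 9270 nM. Compound 3 thus lies within the scatter of compound 1, while compound 2 has the highest number of the three.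

Compound 4 (`C=CS(=O)(=O)N1CCN(c2ncnc3sc(-c4cn(C)nc4C(F)(F)F)cc23)CC1`) carries 1-methyl-3-(trifluoromethyl)-1H-pyrazol-4-yl in place of 6-methoxypyridin-3-yl on the same aromatic carbon, next to the ring sulfur (1-methyl-3-(trifluoromethyl)-1H-pyrazol-4-yl in place of 6-methoxypyridin-3-yl on an aromatic carbon). Three measured steps at this place bear on the change: a 1.2-fold higher number from compound 1 to compound 3 (0.06 log units; within the scatter), a 3.4-fold higher number from compound 1 to compound 2 (0.54 log units; beyond the scatter) and a 3.0-fold lower number from compound 2 to compound 3 (0.48 log units; beyond the scatter). Among the compounds with values here, the largest of these is only modest, and no measured compound has a five-membered ring at this place. In this assay no step beyond the scatter is therefore expected, although a modest step in either direction remains possible.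

The expected change is a 1.3-fold higher number from compound 3 to compound 4 (0.11 log units; within the scatter). For compound 4 the estimated value is 12000 nM, with an expected range from 5000 nM to 30000 nM.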

Compound 4, half-maximal inhibitory concentration: 10400 nM
Beside the measured number, compound 4's estimate is 1.2-fold (0.06 log units) above it; the measured number falls inside the stated range.
By their numbers in this assay, from the lowest: compounds 1, 3 and 4 (each within the scatter of the next); then compound 2.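

The five-membered ring of compound 4 brings no separation from the six-membered rings at this place: in this assay there is a 1.1-fold higher number from compound 3 to compound 4 (0.05 log units; within the scatter) and also a 1.3-fold higher number from compound 1 to compound 4 (0.11 log units; within the scatter). So 1-methyl-3-(trifluoromethyl)-1H-pyrazol-4-yl, 6-methoxypyridin-3-yl and 4-cyanophenyl give numbers that cannot be told apart, despite their different ring sizes and hetero atoms, while a 2.7-fold lower number from compound 2 to compound 4 (0.43 log units; beyond the scatter) leaves 2-chloropyridin-4-yl alone with the highest number. Nothing available explains why that one group stands apart from the other three.

As far as these compounds go, all four compounds carry an aromatic ring at this place, so it remains open whether a morpholine, a carboxylic acid or a longer alkyl chain there would move the number beyond the scatter. From the compounds shown here alone, it is also open whether any group at this place can bring the number well below those of compound 1 and compound 3.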